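Phenyl for methyl on the core of compound 3

The source may hold more compounds than are shown below. What is called first, only, known or untested is meant among the compounds shown, and "the series" means these compounds.

Measured compounds:
compound 1, `O=C(/C=C/c1cccc(Br)n1)c1ccc(Nc2cc(-c3ccccc3)nc3nc(SCc4ccccc4)nn23)cc1`, 38.3%
compound 2, `Cc1cc(Nc2ccc(C(=O)/C=C/c3cccc(Br)n3)cc2)n2nc(SCc3ccccc3[N+](=O)[O-])nc2n1`, 92.3%
compound 3, `C#CCSc1nc2nc(C)cc(Nc3ccc(C(=O)/C=C/c4cccc(Br)n4)cc3)n2n1`, 94.4%

Of the compounds shown here, three built on one shared core have been tested in a functional assay on MGC-803 cells (Homo sapiens) for inhibition, read by sulforhodamine B assay, with a stated time of 72 h, tested at 10 uM; on this read-out lower numbers stand for less inhibition and higher numbers for more inhibition at the one concentration tested (going by the name of the read-out). Compound 3 gives the highest of the three numbers. Its nearest neighbour is compound 2, and the step of a number 2.1 percentage points higher from compound 2 to compound 3 (within the scatter) lies within the scatter, so these two cannot be ranked against each other. Compound 1 sits far lower, beyond the scatter.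

Compound 4, `C#CCSc1nc2nc(-c3ccccc3)cc(Nc3ccc(C(=O)/C=C/c4cccc(Br)n4)cc3)n2n1`, is the next compound. It differs from compound 3 in one place: phenyl in place of methyl on an aromatic carbon.

Going by the values given here, no measured step exchanges a methyl for a phenyl at this aromatic carbon. Among the compounds with values here, the only measured step, from compound 2 to compound 3, concerns the chain on the sulfur and was within the scatter. Compound 1 does carry a phenyl at the same carbon and shows a low number, but it also differs from compound 3 in the group on the sulfur, so its low value cannot be pinned to the phenyl alone. The expectation for compound 4 therefore rests on weak ground: a drop of a number 24.4 percentage points lower from compound 3 to compound 4 (beyond the scatter) is estimated, with wide uncertainty. Compound 4 is expected to give about 70%, most likely between 35% and 95%.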

Compound 4, a percentage reported as inhibition, at one concentration (the size of the read-out at that concentration, not a potency): 56.3%
The estimate for compound 4 lay 13.7 percentage points above the measured number, and the stated range covers the measured number.
By their numbers in this assay, from the lowest: compound 1; then compound 4; then compounds 2 and 3 (each within the scatter of the next).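

In this assay, the exchange of methyl for phenyl on this aromatic carbon gives a number 38.1 percentage points lower from compound 3 to compound 4 (beyond the scatter). Going by these compounds alone, only this one place changes, so the earlier doubt is settled for this pair: with ethynyl on the saturated chain carbon bound to the sulfur, phenyl on the core goes with a large loss of inhibition at the one concentration tested. The phenyl core also allows a second clean reading at the other end of the molecule, where ethynyl in place of phenyl on that chain carbon gives a number 18 percentage points higher from compound 1 to compound 4 (beyond the scatter), showing that the group on the sulfur still moves the number when phenyl sits on the core, though nothing shown explains either step.

As far as these compounds go, with only methyl and phenyl seen at this carbon, it remains open how an ethyl, a cyclopropyl or an amine there would compare, and so whether the number falls gradually or only with a full aromatic ring. Each number is also a single reading at one concentration in one cell line, so these steps give the size of the inhibition at that concentration and not a potency.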